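Isopropoxy in place of fluoro: compound 2 to compound 3

This account rests on a few compounds, and the source may have more. Where it says the series, first, only, none or still open, it means among the compounds named here.

Of the compounds shown here, two have been read so far in a functional assay on MDA-MB-231 cells (Homo sapiens) for antiproliferative activity, read by sulforhodamine B assay, with a stated time of 72 h; on this read-out higher numbers stand for weaker inhibition and lower numbers for stronger inhibition. Compound 1 `COc1c(OC(C)C)cc2occ(-c3csc4ccccc34)c(=O)c2c1OC(C)C` gives > 10000 nM in this assay, and this is a limit of the assay, not a number. Within the data shown here, compound 2 `O=C(/C=C/c1csc2ccccc12)c1cc(F)ccc1O` gives 8400 nM in this assay, the only actual number so far.

The next compound to be read is compound 3 `CC(C)Oc1ccc(O)c(C(=O)/C=C/c2csc3ccccc23)c1`. It carries isopropoxy in place of fluoro on an aromatic carbon, meta to a large group and para to a hydroxy group: isopropoxy in place of fluoro on an aromatic carbon. Among the measured compounds shown here, no measured pair shows what this change does, so the expectation has only one anchor, compound 2 at 8400 nM. Going by these compounds, no shift beyond the usual scatter is expected in this assay, and the direction remains open. The expected change is a 1.4-fold lower number from compound 2 to compound 3 (0.15 log units; within the scatter). For compound 3 the estimated value is 6000 nM, within an expected range of 1500 nM to 15000 nM.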

Compound 3, half-maximal inhibitory concentration: 8500 nM
For compound 3 the middle estimate is 1.4-fold (0.15 log units) below the measured one, and the stated range covers the measured number.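

In this assay, among these compounds, the step at this position, on an aromatic carbon meta to a large group and para to a hydroxy group, is the first that can be read: isopropoxy in place of fluoro gives a 1.0-fold higher number from compound 2 to compound 3 (0.01 log units; within the scatter). A group of 4 heavy atoms, carrying 1 hydrogen-bond acceptor, thus stands where a single fluorine stood without a shift beyond the scatter, so at this level of activity the position tolerates both groups. Compound 1 stays a limit of the assay and not a number, and the pair reads close to that ceiling, so a further weakening from changes at this position could not be sized as a number: the limit of > 10000 nM in this assay, at which 1 of the 3 values shown sits.

The compounds shown leave open whether any group at this position can move the number beyond the scatter in either direction, and an amine, a carboxylic acid or a longer alkoxy chain there would test this. Among the compounds shown here, also open is what the hydroxy group contributes, since no pair shows a methoxy group or a hydrogen in its place.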